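The source may hold more compounds than are shown below. What is called first, only, known or untested is meant among the compounds shown, and "the series" means these compounds.

Measured so far:
compound 1, `O=C(Nc1nnc(-c2cccc(O)c2O)s1)c1ccc(Cl)cc1`: 30200 nM
compound 2, `O=C(Nc1nnc(-c2ccc(O)c(O)c2)s1)C1CCCCC1`: 37300 nM

In a functional assay, with a stated time of 30 min, in the absence of a further agent (on this read-out lower numbers stand for stronger inhibition and higher numbers for weaker inhibition), compound 1 gives 30200 nM and compound 2 gives 37300 nM; the two numbers sit within the usual scatter of each other, so neither compound stands apart on what has been measured. Compound 3, `CC(=O)Nc1nnc(-c2cccc(O)c2O)s1`, is not yet measured in this assay. It differs from compound 1 in one place: methyl in place of 4-chlorophenyl on a carbonyl carbon. Within the data shown here, no step between two measured compounds carries this change, so its size is open. A loss of inhibition beyond the scatter seems the more likely outcome, and the step is expected to be a 2.3-fold higher number from compound 1 to compound 3 (0.37 log units; beyond the scatter). Compound 3 is estimated at 70000 nM, with a range from 25000 nM to 200000 nM.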

Compound 3, half-maximal inhibitory concentration: 111000 nM
Estimate against measurement, compound 3: 1.6-fold (0.20 log units) below; low and high end bracket the measured number.
By their numbers in this assay, from the lowest: compounds 1 and 2 (each within the scatter of the next); then compound 3.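

In this assay, methyl in place of 4-chlorophenyl on a carbonyl carbon gives a 3.7-fold higher number from compound 1 to compound 3 (0.57 log units; beyond the scatter). Among these compounds, the earlier compounds offered no step at this place; this is the first sign that the group on the carbonyl carbon affects inhibition, with weaker inhibition for methyl than for 4-chlorophenyl. Nothing at hand accounts for the size or direction of this step.

Open, going by these compounds, is whether the ring or the chlorine carries the difference, which plain phenyl would help separate. Also open, on these data alone, is how a longer chain such as butyl or a basic amine would read at this place.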